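The source may hold more compounds than are shown below. What is called first, only, known or untested is meant among the compounds shown, and "the series" means these compounds.

Compound 1, `CCOC(=O)N1CCC(=NNC(=O)c2ccc(C(F)(F)F)cc2)CC1`, gives > 400000 nM in a toxicity assay on BJ cells (Homo sapiens) for cytotoxicity, read by MTT assay, with a stated time of 24 h; a higher number here means a weaker inhibitor, a lower number a stronger inhibitor.
Compound 2, `COc1ccc(C(=O)NN=C2CC(c3ccccc3)NC(c3ccccc3)C2)cc1`, gives > 400000 nM.

The value of compound 1 is a limit of this assay, not a number. The value of compound 2 is likewise a limit and not a number. For the measured compounds named here, compound 2 therefore cannot be placed against compound 1 in this assay: the limit of > 400000 nM in this assay, at which 2 of the 2 values shown sit, so the two measured compounds are indistinguishable on what has been recorded, and no measured step between them exists.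

Compound 3, `O=C(NN=C1CC(c2ccccc2)NC(c2ccccc2)C1)c1ccc([N+](=O)[O-])cc1`, differs from compound 2 in one place: nitro in place of methoxy on an aromatic carbon. Nothing measured here tells how this change acts in this assay, and both measured compounds sit at the limit, so the step expected from compound 2 to compound 3 in this assay is estimated as a step that the limit leaves unreadable from compound 2 to compound 3, that is, nothing beyond the scatter. Compound 3 is accordingly expected to give about 500000 nM, somewhere between 150000 nM and 2000000 nM, and most probably this assay would again report only a limit for it rather than a number.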

Compound 3, half-maximal inhibitory concentration: > 400000 nM
Compound 3 gave a limit, no number; the forecaster's own chance of this, stated with the estimate: 80%; the middle value is on the limit's open side.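

In this assay compound 3 gives > 400000 nM, a limit and not a number. No step can therefore be read between compound 2 and compound 3, and the three compounds shown share one reading: the limit of > 400000 nM in this assay, at which 3 of the 3 values shown sit.

The compounds shown leave open how nitro in place of methoxy acts in this assay, and what number any of them would give.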